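From a Two-Ring Group to 4-Methoxycyclohexyl

The source may report more compounds than this note shows. Statements on the series, on what has been measured and on what is new or still open speak of the compounds shown alone.

- Compound 1 `CNC(=O)Nc1ccc(-c2nc(N3CC4CCC(C3)O4)c3cnn([C@H]4CC[C@@H](O)CC4)c3n2)cc1` gives > 0.5 h (a limit)
- Compound 2 `CNC(=O)Nc1ccc(-c2nc(N3CC4CCC(C3)O4)c3cnn(C4CCC5(CC4)OCCCO5)c3n2)cc1` gives > 0.5 h (a limit)

In an in vitro ADME assay on microsomes (Mus musculus) for metabolic stability (on this read-out higher numbers stand for a longer-lived compound and lower numbers for a shorter-lived compound), compound 2 gives > 0.5 h and this is a limit of the assay, not a number. Compound 2 therefore stands at the limit of > 0.5 h in this assay, at which 2 of the 2 values shown sit, and has no exact half-life to start from.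

The next compound to be measured is compound 3 `CNC(=O)Nc1ccc(-c2nc(N3CC4CCC(C3)O4)c3cnn([C@H]4CC[C@@H](OC)CC4)c3n2)cc1` and the change that leads to it is a group of 8 heavy atoms (7 carbon, 1 oxygen; one six-membered non-aromatic ring of carbon only) in place of a group of 11 heavy atoms (9 carbon, 2 oxygen; one six-membered non-aromatic ring of carbon only, one six-membered non-aromatic ring with 2 hetero atoms), on an aromatic nitrogen on an aromatic nitrogen.

Among the compounds with values here, the one measured step that bears on this change is a step that the two limits leave unreadable from compound 1 to compound 2 and it sits on the same aromatic nitrogen. Its size gives no guide, so there is no measured reason to expect a move up or down. The expectation is therefore a step that the limit leaves unreadable from compound 2 to compound 3 with no shift beyond the usual scatter in either direction.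

For compound 3 the estimate is 0.6 h with an expected range from 0.3 h to 1.2 h and the assay may well report only a limit again.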

Compound 3, half-life: 0.283 h
Compound 3: the middle estimate sits 2.1-fold (0.33 log units) above what was measured; measured number below the stated range.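

At this aromatic nitrogen, 4-methoxycyclohexyl gives the first exact half-life in this assay, and replacing the two-ring group of compound 2 with it gives an at least 1.7-fold lower number from compound 2 to compound 3 (0.24 log units; that floor lies within the scatter). Placing methyl instead of hydrogen on the oxygen of compound 1, a smaller change at the same position, gives an at least 1.7-fold lower number from compound 1 to compound 3 (0.24 log units; that floor lies within the scatter). Compound 1 and compound 2 each stand at a limit, so these two steps show only a floor and not a full size: the limit of > 0.5 h in this assay, at which 2 of the 3 values shown sit.

The compounds shown leave open how far the half-lives of compound 1 and compound 2 reach, and therefore whether either step goes beyond the usual scatter. They also leave open how a longer chain on that oxygen, such as ethyl, or an amine in its place on the cyclohexyl ring would read in this assay.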